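Replacing Isopropyl with Cyclobutyl on the Aryl Ether

The compounds below may be only part of what the source reports. "The series", "measured", "known", "first", "only" and "open" are said of these compounds alone.

Measured compounds:
- compound 1 `CCCCCOc1cc(CCc2nc(C)c(CC)s2)nc(NCc2cc(Cl)cc(NC(=O)OC(C)C)c2)c1`: 35 nM
- compound 2 `CCc1sc(CCc2cc(OC(C)C)cc(NCc3cc(Cl)cc(NC(=O)OC(C)C)c3)n2)nc1C`: 12 nM

Among the compounds with values here, in an assay on cells for binding affinity to Neuropeptide Y receptor type 1 (Homo sapiens) (a higher number here means a weaker inhibitor, a lower number a stronger inhibitor), compound 2 gives 12 nM, the lower of the two numbers so far, and its only neighbour is compound 1 with 35 nM. Within the data shown here, the one step measured between them, a 2.9-fold lower number from compound 1 to compound 2 (0.46 log units; beyond the scatter), came from putting isopropyl in place of pentyl on an oxygen on an aromatic ring, so a shorter group at that oxygen went with the lower number.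

Compound 3 `CCc1sc(CCc2cc(OC3CCC3)cc(NCc3cc(Cl)cc(NC(=O)OC(C)C)c3)n2)nc1C` is not yet measured. It differs from compound 2 in one place: cyclobutyl in place of isopropyl on an oxygen on an aromatic ring. This is the same oxygen that was changed in the step from compound 1 to compound 2, so that step is the only one that bears on it. Cyclobutyl carries one more carbon than isopropyl but closes it into a ring, so its size sits between the two groups already seen; the single measured step gives no direct guide to a ring at this position.

For compound 3 a step of a 1.3-fold higher number from compound 2 to compound 3 (0.10 log units; within the scatter) is expected, within the scatter, and its estimated value in this assay is 15 nM, in a range from 6 nM to 40 nM.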

Compound 3, half-maximal inhibitory concentration: 11 nM
For compound 3 the middle estimate is 1.4-fold (0.13 log units) above the measured one, within the range that was stated.
By their numbers in this assay, from the lowest: compounds 3 and 2 (each within the scatter of the next); then compound 1.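

In this assay, the new step is a 1.1-fold lower number from compound 2 to compound 3 (0.04 log units; within the scatter), so at this oxygen on the aromatic ring, a cyclobutyl ring and an open isopropyl group cannot be told apart, and a ring is accepted here without any loss in the reading. The other new step, a 3.2-fold lower number from compound 1 to compound 3 (0.50 log units; beyond the scatter), is close in size to the one already seen for isopropyl in place of pentyl, so among these three compounds, compound 1 with its pentyl group stands apart, while the two smaller groups sit together. Nothing in the data shown explains why the ring and the isopropyl group read alike.

Within the data shown here, only three groups on this oxygen appear here, so how a methyl group, a larger cyclohexyl ring or a chain ending in an amine would read remains open. As far as these compounds go, it is also open whether cyclobutyl and isopropyl would still read alike if another part of the shared core were changed.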